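The source may report more compounds than this note shows. Statements on the series, on what has been measured and on what is new or still open speak of the compounds shown alone.

Measured so far:
compound 1 `Cc1cccc(/C(N)=N/NC(=S)N2CCN(c3ccccn3)CC2)n1`, in a functional assay on A-431 cells (Homo sapiens) for cytotoxicity, read by MTT assay, with a stated time of 72 h, tested at 100 uM (a higher number here means more inhibition of growth at the concentration tested, a lower number less inhibition of growth), compound 1 gives 78.9%
compound 2 `N/C(=N\NC(=S)N1CCCC1)c1ccc(F)cn1`, in this assay compound 2 gives 85.6%

Compound 2 holds the highest of the two numbers in this assay, but its nearest neighbour, compound 1, sits within the usual scatter of it, so no order between the two can be read from these values. Among the measured compounds shown here, the two measured compounds also differ from each other in more than one place, so no single step between them is available as a guide.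

Compound 3 `N/C(=N\NC(=S)N1CCSCC1)c1ccc(F)cn1` has not yet been measured in this assay. Its difference from compound 2 is thiomorpholin-4-yl in place of pyrrolidin-1-yl on a thiocarbonyl carbon. For the measured compounds named here, nothing among the measured compounds isolates this change, so there is no measured step to lean on. The expectation is a step from compound 2 to compound 3 of a number 5.6 percentage points lower from compound 2 to compound 3 (within the scatter), that is, no move beyond the scatter in either direction, with a modest chance of a small drop. For compound 3 in this assay the estimated value is 80%, with a range from 60% to 95%.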

Compound 3, percent growth inhibition at one concentration: 86.6%
The estimate for compound 3 lay 6.6 percentage points below the measured number; low and high end bracket the measured number.
By their numbers in this assay, from the lowest: compounds 1, 2 and 3 (each within the scatter of the next).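

In this assay, among the compounds shown here, the read-out moves a number 1 percentage points higher from compound 2 to compound 3 (within the scatter), which gives the first measured step at this position, on a thiocarbonyl carbon whose other neighbour is an amide-type nitrogen. Thiomorpholin-4-yl in place of pyrrolidin-1-yl swaps a five-membered ring for a six-membered ring with a second hetero atom, sulfur, and adds a hydrogen-bond acceptor to the count, yet the step stays within the scatter, so on this core the position accepts both rings without a readable difference at the single concentration tested. No measured information is at hand to account for the two rings reading alike.

From the compounds shown here alone, whether the sulfur atom plays any part stays open, and morpholin-4-yl, with oxygen in its place, would be the direct comparison, while an open-chain dimethylamino group on the same thiocarbonyl carbon would show whether a ring is needed at all. With one step, and that step within the scatter, the compounds shown also leave open whether any group at this position can move the read-out beyond the scatter.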